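This account rests on a few compounds, and the source may have more. Where it says the series, first, only, none or still open, it means among the compounds named here.

Measured compounds:
compound 1 `CN(C)C(=O)c1cc(-c2cnc(NCc3c(F)ccc4c3CCO4)c3cn[nH]c(=O)c23)n(C)n1`, 21 mL.min-1.g-1
compound 2 `O=C1CCCN1c1cnc(NCc2c(F)ccc3c2CCO3)n2cnnc12`, < 3 mL.min-1.g-1

Of the compounds shown here, two sharing the same core have been measured in an ADME assay on microsomes from liver (Homo sapiens) for metabolic stability, read by LC-MS, using NADPH, with stated times of 5 min and 30 min, tested at 1 uM; a higher number here means faster removal of the compound, a lower number slower removal. In this assay compound 1 `CN(C)C(=O)c1cc(-c2cnc(NCc3c(F)ccc4c3CCO4)c3cn[nH]c(=O)c23)n(C)n1` gives 21 mL.min-1.g-1. Compound 2 `O=C1CCCN1c1cnc(NCc2c(F)ccc3c2CCO3)n2cnnc12` returns only a limit of the assay, < 3 mL.min-1.g-1, so no number is available for it. Within the data shown here, compound 1 therefore stands as the only numerical value in the set, while the other entry sits at the limit of < 3 mL.min-1.g-1 in this assay, at which 1 of the 2 values shown sits.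

Compound 3 `Cc1nn(C)cc1-c1cnc(NCc2c(F)ccc3c2CCO3)c2cn[nH]c(=O)c12` differs from compound 1 in a single place: 1,3-dimethyl-1H-pyrazol-4-yl in place of 3-(dimethylcarbamoyl)-1-methyl-1H-pyrazol-5-yl on an aromatic carbon. Among the measured compounds shown here, no pair of measured compounds differs by this change alone, so there is no measured step to lean on. On the evidence at hand, the exchange is expected to move the read-out only modestly, with no step beyond the usual scatter of this assay in either direction; the expected step is a 1.4-fold lower number from compound 1 to compound 3 (0.15 log units; within the scatter). Compound 3 is accordingly estimated at 15 mL.min-1.g-1, with a range from 5 mL.min-1.g-1 to 45 mL.min-1.g-1, before its own measurement is known.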

Compound 3, intrinsic clearance in microsomes: 27 mL.min-1.g-1
Estimate against measurement, compound 3: 1.8-fold (0.26 log units) below; low and high end bracket the measured number.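

Among these compounds, the first measured step at this position, on an aromatic carbon of a six-membered aromatic ring with 1 nitrogen, shows that in this assay the exchange of 3-(dimethylcarbamoyl)-1-methyl-1H-pyrazol-5-yl for 1,3-dimethyl-1H-pyrazol-4-yl gives a 1.3-fold higher number from compound 1 to compound 3 (0.11 log units; within the scatter). This single exchange removes the dimethylcarbamoyl group and also changes the point at which the pyrazole is attached and where its methyl groups sit, yet the read-out stays within the scatter, so at this place the dimethylcarbamoyl group is not required for a value of this size. No measurement shown bears on why the read-out holds across this exchange.

The compounds shown leave open whether a group of a different kind at this place, such as a morpholine, an amine or a carboxylic acid, would move the read-out beyond the scatter. They also do not separate the two parts of the exchange, which would take a pair such as the 1-methyl-1H-pyrazol-5-yl ring with and without its dimethylcarbamoyl group.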